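The compounds below may be only part of what the source reports. "The series", "measured", "known", "first", "only" and "open" are said of these compounds alone.

Measured so far, in a functional assay on A549 cells (Homo sapiens) for inhibition; a lower number here means a stronger inhibitor, a higher number a weaker inhibitor:
compound 1 `CC(C)c1cc(-c2n[nH]c(=O)n2-c2cccc(C(=O)NCCCC(=O)NO)c2)c(O)cc1O`, 4600 nM;
compound 2 `CC(C)c1cc(-c2n[nH]c(=O)n2-c2cccc(C(=O)NCCCCC(=O)NO)c2)c(O)cc1O`, 4600 nM;
compound 3 `CC(C)c1cc(-c2n[nH]c(=O)n2-c2ccc(C(=O)NCCCCCC(=O)NO)cc2)c(O)cc1O`, 4600 nM.

Compound 1 and compound 2 share one core; the step between them is hydroxycarbamoyl in place of (hydroxycarbamoyl)methyl on a saturated chain carbon, three bonds along the chain from an amide-type nitrogen, and its size is no change at the digits printed from compound 2 to compound 1 (within the scatter). Compound 3 carries a different core; how it differs from the core of compound 2 is not broken down here, and compound 3 sits level with compound 1 and compound 2 at the digits given.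

Compound 4 `CC(C)c1cc(-c2n[nH]c(=O)n2-c2ccc(C(=O)NCCCCC(=O)NO)cc2)c(O)cc1O` is not yet measured. It differs from compound 3 by hydroxycarbamoyl in place of (hydroxycarbamoyl)methyl on a saturated chain carbon, four bonds along the chain from an amide-type nitrogen. For the measured compounds named here, this is the same kind of change as the one from compound 2 to compound 1, not the same: there the place is three bonds along the chain from an amide-type nitrogen, here it is four bonds along. Beside the earlier step, the step from compound 3 to compound 4 in this assay is expected to be no change at the digits printed from compound 3 to compound 4 (within the scatter), resting on compound 2 and compound 1 showing no change at the digits printed from compound 2 to compound 1 (within the scatter). Compound 4 is therefore estimated at 4600 nM, between 2300 nM and 9200 nM.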

Compound 4, half-maximal inhibitory concentration: 4600 nM
For compound 4 middle estimate and measured number coincide at the digits printed; the range from low to high includes it.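

In this assay, hydroxycarbamoyl in place of (hydroxycarbamoyl)methyl gives no change at the digits printed from compound 3 to compound 4 (within the scatter). Set beside the earlier step on the other core, at a different place along the chain, the change carries over with no difference that can be read: the same change on two cores in this assay, no change at the digits printed (within the scatter) from compound 2 to compound 1 and no change at the digits printed (within the scatter) from compound 3 to compound 4, 1.0-fold (0.00 log units) apart, within the scatter of two such steps This shows only that a step of no measurable size repeats on a second core; since all the values here are level, it does not show that the change would carry over on a core where it shifts the read-out, and it says nothing about cores other than these two.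

The compounds shown leave open whether a longer chain than that of compound 3 would depart from the shared level, which compound 1 marks at 4600 nM. They also leave open whether a carboxylic acid or an amine at the chain end, in place of hydroxycarbamoyl, would separate the two cores in this assay.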